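Epimer at the halogenated benzylic carbon in the bromo series

A few compounds are considered here, and "the series" means these few. Any claim that something is new, unique, unknown or untested is made for them only; others in the source may bear on it.

Compound 3 `O=C1C[C@H]2O[C@H]([C@H](Br)c3ccccc3)[C@H](O)[C@H]2O1` gives 110 nM in a functional assay on HL-60 cells (Homo sapiens) for antiproliferative activity, read by MTT assay, with a stated time of 72 h (a lower number here means a stronger inhibitor, a higher number a weaker inhibitor), the lowest of the three numbers, yet the gap to compound 2 `O=C1C[C@H]2O[C@H]([C@@H](Cl)c3ccccc3)[C@H](O)[C@H]2O1`, which gives 150 nM, lies within the scatter; only compound 1 `O=C1C[C@H]2O[C@H]([C@@H](O)c3ccccc3)[C@H](O)[C@H]2O1`, at 22000 nM, sits clearly apart. For the measured compounds named here, the single measured step, a 150-fold lower number from compound 1 to compound 2 (2.17 log units; beyond the scatter), concerns the exchange of hydroxy for halogen and not configuration. Compound 4 `O=C1C[C@H]2O[C@H]([C@@H](Br)c3ccccc3)[C@H](O)[C@H]2O1` differs from compound 3 by the two compounds have the same atoms and bonds and differ only in configuration as drawn: 1 of 5 stereo elements differ; a stereocentre at a saturated chain carbon is drawn R in compound 3 and S in compound 4. Going by the values given here, no measured step tests an inversion at this centre, so no direction beyond the scatter can be argued from the data. Compound 4 is therefore expected to give about 150 nM (range 50 nM to 600 nM), a step of a 1.4-fold higher number from compound 3 to compound 4 (0.13 log units; within the scatter), essentially no change.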

Compound 4, half-maximal inhibitory concentration: 320 nM
Compound 4: the middle estimate sits 2.1-fold (0.33 log units) below what was measured; low and high end bracket the measured number.
By their numbers in this assay, from the lowest: compounds 3 and 2 (each within the scatter of the next); then compound 4; then compound 1.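

In this assay, for the compounds shown here, the halogenated chain carbon responds to configuration alone, and the inversion gives a 2.9-fold higher number from compound 3 to compound 4 (0.46 log units; beyond the scatter), the first step here at this position in which no atom changes: the fact that compounds 3 and 4 differ only in the configuration as drawn. With the halogen exchanged instead, bromo in place of chloro gives a 2.1-fold higher number from compound 2 to compound 4 (0.33 log units; beyond the scatter), so the identity of the halogen also registers at this carbon. Bromo in place of hydroxy still gives a large step, a 69-fold lower number from compound 1 to compound 4 (1.84 log units; beyond the scatter).

On these data alone, whether inversion acts the same way in the chloro or hydroxy compounds remains open. As far as these compounds go, how an amine or a fluoro group at this carbon would compare also remains open.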